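Amide cap variation on the azole ether series

The source may hold more compounds than are shown below. What is called first, only, known or untested is meant among the compounds shown, and "the series" means these compounds.

Two amides sharing one core have been measured. Compound 1 `CCCC(=O)Nc1ccc(N2CCN(c3ccc(OC[C@@H]4CO[C@@](Cn5cncn5)(c5ccc(Cl)cc5Cl)O4)cc3)CC2)cc1` carries a propyl on its carbonyl carbon, and in a functional assay on HepG2 cells (Homo sapiens) for inhibition, read by MTT assay, with a stated time of 48 h (a lower number here means a stronger inhibitor, a higher number a weaker inhibitor), compound 1 gives 9930 nM. Compound 2 `O=C(Nc1ccc(N2CCN(c3ccc(OC[C@@H]4CO[C@@](Cn5cncn5)(c5ccc(Cl)cc5Cl)O4)cc3)CC2)cc1)c1ccc(F)c(F)c1` carries a 3,4-difluorophenyl there instead, and in this assay compound 2 gives 19900 nM. Compound 1 thus holds the lowest of the two numbers, but the step of a 2.0-fold higher number from compound 1 to compound 2 (0.30 log units; within the scatter) stays within the scatter, so the two cannot be ordered.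

Compound 3 `Cc1ccc(C(=O)Nc2ccc(N3CCN(c4ccc(OC[C@@H]5CO[C@@](Cn6cncn6)(c6ccc(Cl)cc6Cl)O5)cc4)CC3)cc2)o1` has not been measured. It differs from compound 1 by 5-methylfuran-2-yl in place of propyl on a carbonyl carbon. For the measured compounds named here, the only step that bears on this is the one from compound 1 to compound 2, where an aromatic ring also replaced propyl on the carbonyl carbon and gave a 2.0-fold higher number from compound 1 to compound 2 (0.30 log units; within the scatter). A change of similar size, at most a small drift to a higher number, is therefore expected for compound 3 in this assay, as a 1.4-fold higher number from compound 1 to compound 3 (0.15 log units; within the scatter). Compound 3 is estimated at 14000 nM, with a range from 5000 nM to 40000 nM.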

Compound 3, half-maximal inhibitory concentration: 8700 nM
Compound 3: the middle estimate sits 1.6-fold (0.21 log units) above what was measured; measured number inside the range.
By their numbers in this assay, from the lowest: compounds 3, 1 and 2 (each within the scatter of the next, the first and the last beyond it).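

In this assay, the step from propyl to 5-methylfuran-2-yl on the carbonyl carbon reads as a 1.1-fold lower number from compound 1 to compound 3 (0.06 log units; within the scatter), so this five-membered aromatic ring with its oxygen cannot be told apart from the propyl cap. For the compounds shown here, the choice between the two aromatic caps does register, as a 2.3-fold lower number from compound 2 to compound 3 (0.36 log units; beyond the scatter), and this is the first modest separation at this position, which shows that an aromatic ring here does not carry one fixed outcome. Nothing measured on these compounds accounts for that separation.

As far as these compounds go, whether a longer chain in place of propyl, or an amine or a carboxylic acid carried on the cap, would move the number beyond the scatter from compound 1 remains open. Also open, from the compounds shown here alone, is whether any change outside the amide cap would shift the number further than these caps do.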